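This account rests on a few compounds, and the source may have more. Where it says the series, first, only, none or still open, it means among the compounds named here.

In a functional assay on B16-F10 cells (Mus musculus) for antiproliferative activity, read by MTT assay, with a stated time of 48 h (a higher number here means a weaker inhibitor, a lower number a stronger inhibitor), compound 1 (`COc1ccc(C2OC(c3ccc4ccccc4c3)=NN2C(C)=O)cc1`) gives 6.86 ug/mL and compound 2 (`CC(=O)N1N=C(c2ccc3ccccc3c2)OC1c1ccccc1Br`) gives 6.98 ug/mL. The measured step, a 1.0-fold higher number from compound 1 to compound 2 (0.01 log units; within the scatter), does not separate them. Compound 3 (`CC(=O)N1N=C(c2ccc3ccccc3c2)OC1c1ccc(Cl)cc1`) gives 2.48 ug/mL, the lowest of the three numbers and the strongest inhibition measured so far in the series.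

Compound 4 (`CC(=O)N1N=C(c2ccc3ccccc3c2)OC1c1ccc(F)cc1`) carries fluoro in place of chloro on an aromatic carbon, para to a large group: fluoro in place of chloro on an aromatic carbon. Among the compounds with values here, no measured step makes this exact exchange. The closest is a 2.8-fold lower number from compound 1 to compound 3 (0.44 log units; beyond the scatter), which changes the group at the same place. Also relevant is a 2.8-fold lower number from compound 2 to compound 3 (0.45 log units; beyond the scatter), which goes from 2-bromophenyl to 4-chlorophenyl. Both steps are modest and both end at compound 3, so neither shows how a second halogen behaves here. A step no larger than these is expected in this assay, most likely within the scatter and leaning towards a higher number, given that compound 3 at 2.48 ug/mL is the lowest so far. The estimated change is a 1.5-fold higher number from compound 3 to compound 4 (0.19 log units; within the scatter). For compound 4 the expected value is 3.8 ug/mL, with an estimated range of 1.8 ug/mL to 7.5 ug/mL.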

Compound 4, half-maximal inhibitory concentration: 4.65 ug/mL
For compound 4 the middle estimate is 1.2-fold (0.09 log units) below the measured one, within the range that was stated.
By their numbers in this assay, from the lowest: compounds 3, 4, 1 and 2 (each within the scatter of the next, the first and the last beyond it).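

In this assay, within the data shown here, this is the first exchange of one halogen for another on the aromatic carbon para to a large group, and with a 1.9-fold higher number from compound 3 to compound 4 (0.27 log units; within the scatter) chloro and fluoro are not separated. Among these compounds, the picture is less clear-cut than the earlier compounds suggested: fluoro also stays close to the other two groups, with a 1.5-fold lower number from compound 2 to compound 4 (0.18 log units; within the scatter) and a 1.5-fold lower number from compound 1 to compound 4 (0.17 log units; within the scatter), so compound 4 lies within the scatter of every other compound, while compound 3 remains beyond it from compound 1 and compound 2. Nothing available bears on the reason for this result.

The compounds shown leave open how an amine, a carboxylic acid or a plain hydrogen at this place would compare with chloro and fluoro, and how 4-bromophenyl would compare with 2-bromophenyl. From the compounds shown here alone, the shared core stays constant throughout, so the effect of any change there also remains open.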